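Piperidine in place of piperazine at the amidine carbon

The source may hold more compounds than are shown below. What is called first, only, known or untested is meant among the compounds shown, and "the series" means these compounds.

Measured compounds:
compound 1 `Cc1nc(N2CCC(C)(O)CC2)nc2ccc(NC(=O)COc3ccc(Cl)cc3)cc12` — 827 nM
compound 2 `CCN1CCN(c2nc(C)c3cc(NC(=O)COc4ccc(Cl)cc4)ccc3n2)CC1` — "not determined" (no result reported)

Compound 1 was tested in a functional assay on CHO-K1 cells for antagonist activity at melanin-concentrating hormone receptor 1 (Homo sapiens), read by inositol phosphate accumulation (on this read-out lower numbers stand for stronger inhibition and higher numbers for weaker inhibition), and gives 827 nM. Compound 2 was included in the series, but its result in this assay is "not determined" (no result reported), so its standing on the read-out cannot be placed from the numbers shown. The step from compound 2 to compound 3 `CCC1(O)CCN(c2nc(C)c3cc(NC(=O)COc4ccc(Cl)cc4)ccc3n2)CC1` is 4-ethyl-4-hydroxypiperidin-1-yl in place of 4-ethylpiperazin-1-yl on an aromatic carbon. Compound 2 carries no number. Going by the values given here, no measured step therefore exists for this change, and its size cannot be drawn from the data. Among the compounds with values here, the author notes only that compound 3 shares with compound 1 a hydroxy-substituted piperidine on the same carbon and differs from it by one carbon in the alkyl group. Compound 3 is therefore expected to lie near compound 1, which gives 827 nM. The estimate for compound 3 in this assay is 650 nM, with a range from 150 nM to 2800 nM.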

Compound 3, half-maximal inhibitory concentration: 384 nM
For compound 3 the middle estimate is 1.7-fold (0.23 log units) above the measured one, within the range that was stated.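

In this assay, going by these compounds alone, the one step that can be read takes the alkyl group on the hydroxy-bearing ring carbon from methyl to ethyl, giving a 2.2-fold lower number from compound 1 to compound 3 (0.33 log units; beyond the scatter), so on this aromatic carbon, between two ring nitrogen atoms, the added carbon comes with a modest move towards stronger inhibition. Compound 2 has no number, so the change from 4-ethylpiperazin-1-yl to 4-ethyl-4-hydroxypiperidin-1-yl cannot be read, and the effect of replacing piperazine with piperidine stays unmeasured in this set. No measurement offered here explains the step between the two hydroxypiperidines.

As far as these compounds go, what a propyl or cyclopropyl group would give on that ring carbon remains open. So does what a methoxy group or an amine would give in place of the hydroxy group in this assay.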